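A few compounds are considered here, and "the series" means these few. Any claim that something is new, unique, unknown or untested is made for them only; others in the source may bear on it.

Measured so far in a functional assay on NCI-H460 cells (Homo sapiens) for inhibition, read by CCK-8 assay, with a stated time of 72 h; on this read-out higher numbers stand for weaker inhibition and lower numbers for stronger inhibition:
- compound 1 `Nc1ccccc1NC(=O)c1ccc(CNC(=O)c2n[nH]cc2NC(=O)c2c(F)cccc2Cl)cc1` gives 3630 nM (lower number)
- compound 2 `O=C(NO)c1ccc(CNC(=O)c2n[nH]cc2NC(=O)c2c(Cl)cccc2Cl)cc1` gives 10600 nM (higher number)

Compound 2 (10600 nM) holds the higher of the two numbers, making it the weaker inhibitor of this pair. Its gap to compound 1 (3630 nM) lies beyond the scatter. These two compounds differ in more than one place, so the gap cannot be assigned to a single change.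

The next compound is compound 3 `Nc1ccccc1NC(=O)c1ccc(CNC(=O)c2n[nH]cc2NC(=O)c2c(Cl)cccc2Cl)cc1`, which differs from compound 2 as follows: 2-aminophenyl in place of hydroxy on an amide-type nitrogen. In words, this is 2-aminophenyl in place of hydroxy on an amide-type nitrogen. Among the compounds with values here, no measured pair isolates this change. Within the data shown here, the only guide is compound 1, which also carries 2-aminophenyl there and gives 3630 nM in this assay, so a number near that one is expected. The expected move, a 3.2-fold lower number from compound 2 to compound 3 (0.51 log units; beyond the scatter), is a moderate one towards stronger inhibition, only modestly beyond the scatter. For compound 3 the estimated value is 3300 nM, with an expected range of 1200 nM to 9000 nM.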

Compound 3, half-maximal inhibitory concentration: 4190 nM
Beside the measured number, compound 3's estimate is 1.3-fold (0.10 log units) below it, and the stated range covers the measured number.
By their numbers in this assay, from the lowest: compounds 1 and 3 (each within the scatter of the next); then compound 2.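

In this assay, 2-aminophenyl in place of hydroxy on an amide-type nitrogen gives a 2.5-fold lower number from compound 2 to compound 3 (0.40 log units; beyond the scatter) as a modest move towards stronger inhibition, so this change is now isolated on an otherwise unchanged structure. The step is read from one pair only, and it shows that the (2-aminophenyl)carbamoyl form holds an advantage over the hydroxycarbamoyl form with chloro kept on the aromatic carbon. Chloro in place of fluoro on an aromatic carbon gives a 1.2-fold higher number from compound 1 to compound 3 (0.06 log units; within the scatter) and therefore no difference that can be told from the scatter on this read-out, while no accompanying measurement offers an explanation for either step.

The compounds shown leave open whether the gain depends on the amino group of 2-aminophenyl or on the aromatic ring itself, which a plain phenyl or a 2-hydroxyphenyl on the same nitrogen would help to separate. They also leave open whether the insensitivity seen between fluoro and chloro extends to other groups on that aromatic carbon, such as a methyl or a methoxy.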